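A few compounds are considered here, and "the series" means these few. Any claim that something is new, unique, unknown or untested is made for them only; others in the source may bear on it.

In a functional assay on the whole organism (stomach) for inhibition, with Rattus norvegicus as the target, at a dose of 100 mg/kg by the intraduodenal route (a lower number here means less inhibition, a higher number more inhibition at the dose given (going by the name of the read-out)), compound 3 `Cc1ccc(=O)n(CC(=N)S)n1` gives 31.5%, the lowest of the three numbers in hand. Its nearest neighbour is compound 1 `CC(Cn1ncccc1=O)C(=N)S`, which in this assay gives 40.3%, a number that lies within the usual scatter of compound 3; the two are therefore not distinguishable. The furthest is compound 2 `N=C(S)CCn1ncccc1=S`, which in this assay gives 50%, a number beyond the scatter above compound 3. No pair among these three differs in just one place, so none of them yields a step that can be carried over to a new compound.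

Compound 4 `Cc1ccc(=O)n(CCC(N)=O)n1` differs from compound 3 in this way: a group of 4 heavy atoms (2 carbon, 1 nitrogen, 1 oxygen; no ring) in place of a group of 3 heavy atoms (1 carbon, 1 nitrogen, 1 sulfur; no ring), on a saturated chain carbon bound to an aromatic nitrogen. Among the measured compounds shown here, with no step between measured compounds to lean on, the expectation rests on the value of compound 3 alone. The step of a number 1.5 percentage points lower from compound 3 to compound 4 (within the scatter) is expected to stay within the scatter, if anything slightly downward. Compound 4 is estimated to give 30% in this assay, within a range of 15% to 48%.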

Compound 4, a percentage reported as inhibition, in the whole organism at one dose (the size of the read-out at that dose, not a potency): -2.9%
Beside the measured number, compound 4's estimate is 32.9 percentage points above it; the measured number lies below the stated range.
By their numbers in this assay, from the lowest: compound 4; then compounds 3, 1 and 2 (each within the scatter of the next, the first and the last beyond it).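

In this assay, exchanging the group that holds the sulfur for carbamoylmethyl, on a saturated chain carbon bound to an aromatic nitrogen, gives a number 34.4 percentage points lower from compound 3 to compound 4 (beyond the scatter). Among the compounds shown here, this is the first comparison in the set that changes one place only, and it shows that the read-out depends strongly on the group at this position, since compound 4 gives -2.9% with the shared core unchanged. Nothing measured here accounts for the size of this step.

The compounds shown leave open whether a carboxylic acid, an amine or a longer chain at this position would restore inhibition or leave it as low as in compound 4. They also leave open whether the same exchange would produce a step of similar size on the cores of compound 1 and compound 2.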